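This account rests on a few compounds, and the source may have more. Where it says the series, first, only, none or still open, it means among the compounds named here.

Measured so far:
- Compound 1, `C=C1[C@H]2O[C@]3([C@@H](C)C(=O)O[C@H]3[C@H]1Cl)[C@@H](OC(C)=O)[C@H]1[C@@]3(CO3)[C@H](OC(=O)CC(C)C)C[C@H](OC(C)=O)[C@]1(C)[C@@H](OC(C)=O)[C@H]2OC(C)=O`: < 300 nM
- Compound 2, `C=C1[C@H](Cl)[C@@H]2OC(=O)[C@H](C)[C@]23O[C@@H]1[C@H](OC(C)=O)[C@H](OC(C)=O)[C@@]1(C)[C@@H](OC(C)=O)CC[C@]2(CO2)[C@@H]1[C@@H]3OC(C)=O`: > 50100 nM

In a functional assay on A549 cells (Homo sapiens) for cytotoxicity, read by MTT assay (a lower number here means a stronger inhibitor, a higher number a weaker inhibitor), compound 1 gives < 300 nM. That value is a limit of the assay rather than a measured number (the limit of < 300 nM in this assay, at which 1 of the 2 values shown sits). Compound 2 gives > 50100 nM in the same assay. This too is a limit, not a number (the limit of > 50100 nM in this assay, at which 1 of the 2 values shown sits). Among the measured compounds shown here, no step between these two compounds is counted here, so all that their two values show is that compound 1 sits at one end of what the assay reports and compound 2 at the other. Where compound 1 stands is therefore known only as far as its limit reaches.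

Compound 3, `C=C1[C@H]2O[C@]3([C@@H](C)C(=O)O[C@H]3[C@H]1Cl)[C@@H](OC(C)=O)[C@H]1[C@@]3(CO3)[C@H](OC(C)=O)C[C@H](OC(C)=O)[C@]1(C)[C@@H](OC(C)=O)[C@H]2OC(C)=O`, has not yet been measured. It differs from compound 1 in one place: hydrogen in place of isopropyl on a saturated chain carbon bound to a carbonyl carbon. Such a change on the ester side chain is expected to move the result little, if at all beyond the usual scatter, perhaps a slight weakening. For compound 3 the estimate is 300 nM, within a range of 60 nM to 1500 nM. This estimate corresponds to an expected step of a number no lower from compound 1 to compound 3 (the limit leaves the size open).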

Compound 3, half-maximal inhibitory concentration: > 45700 nM
Compound 3 gave a limit, no number; the forecaster's own chance of this, stated with the estimate: 40%; at least 150-fold (2.18 log units) between middle value and limit.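

In this assay, putting hydrogen in place of isopropyl on a saturated chain carbon bound to a carbonyl carbon, which turns the isobutylcarbonyl side chain into a plain acetyl, gives an at least 150-fold higher number from compound 1 to compound 3 (2.18 log units; beyond the scatter). Among the compounds shown here, the two earlier compounds had no step between them and only marked the two ends of what this assay reports, whereas this pair ties that span to a single place on the shared core, so a small change in the ester side chain is enough to carry a compound from one end to the other. For compound 3 the reading is a limit and not a number: the limit of > 45700 nM in this assay, at which 1 of the 3 values shown sits.

On these data alone, the real size of the step stays open, with limits at both of its ends, and so does what this place needs, as a propyl chain, a longer straight chain or a benzoyl ester could show whether the loss sets in gradually or all at once. The compounds shown also give no reason why the isopropyl end of the chain matters, and a comparison of this one pair cannot supply one.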